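The source may hold more compounds than are shown below. What is called first, only, known or untested is meant among the compounds shown, and "the series" means these compounds.

Values in a functional assay on HeLa cells (Homo sapiens) for antiproliferative activity, read by MTT assay, with a stated time of 48 h (a lower number here means a stronger inhibitor, a higher number a weaker inhibitor), for the three measured compounds:
- compound 1 `Fc1ccc(-c2nn(-c3ccccc3)cc2-c2nc3cc(Cl)ccc3[nH]2)cc1` gives 2770 nM
- compound 2 `Fc1ccc(-c2nn(-c3ccccc3)cc2-c2nc3cc(Cl)c(Cl)cc3[nH]2)cc1` gives 11600 nM
- compound 3 `Cc1ccc2[nH]c(-c3cn(-c4ccccc4)nc3-c3ccc(Cl)cc3)nc2c1` gives 5360 nM

In this assay compound 2 holds the highest number of the three, with compound 3 the nearest and compound 1 the furthest, both gaps beyond the scatter. The change under study leads to compound 4 `COc1ccc(-c2nn(-c3ccccc3)cc2-c2nc3cc(Cl)c(Cl)cc3[nH]2)cc1` with methoxy in place of fluoro on an aromatic carbon, 4-fluorophenyl to 4-methoxyphenyl, para to a large group (methoxy in place of fluoro on an aromatic carbon). Among the measured compounds shown here, the one measured step, chloro in place of hydrogen on an aromatic carbon, is a 4.2-fold higher number from compound 1 to compound 2 (0.62 log units; beyond the scatter) and lies elsewhere on the molecule, so it gives only a rough idea of how far a single change can move the number. For the measured compounds named here, compound 3 differs from compound 1 in more than one place and offers no clean step. Going by the values given here, no measured step isolates the 4-fluorophenyl group. No step beyond the scatter is therefore expected in this assay for this change, with a slight lean to a lower number because compound 2 stands at 11600 nM as the highest of the three. The estimated step is a 1.5-fold lower number from compound 2 to compound 4 (0.16 log units; within the scatter) for now. For compound 4 the estimated value is 8000 nM with an expected range from 2500 nM to 25000 nM pending measurement.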

Compound 4, half-maximal inhibitory concentration: 6600 nM
Compound 4: the middle estimate sits 1.2-fold (0.08 log units) above what was measured; measured number inside the range.
By their numbers in this assay, from the lowest: compounds 1, 3, 4 and 2 (each within the scatter of the next, the first and the last beyond it).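

In this assay, among the compounds shown here, replacing fluoro with methoxy on this aromatic carbon, para to a large group, gives a 1.8-fold lower number from compound 2 to compound 4 (0.24 log units; within the scatter), the first reading at this position, and 4-fluorophenyl to 4-methoxyphenyl yields no step that can be told apart from repeat measurement. The entering methoxy brings a hydrogen-bond acceptor and one more heavy atom than fluoro, and the series accepts both here without a step beyond the scatter, whereas the chloro change elsewhere on the molecule gives a 4.2-fold higher number from compound 1 to compound 2 (0.62 log units; beyond the scatter) and does lie beyond it. For the compounds shown here, no evidence on the compounds bears on this result.

From the compounds shown here alone, this reading comes from a single pair carrying both chloro groups of compound 2, so it remains open whether the same change would read the same way on the core of compound 1, which carries only one. Also open is whether a longer chain such as ethoxy, an amine or a carboxylic acid at this place would move the number beyond the scatter, since fluoro and methoxy alone span this position among the compounds shown.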